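Carboxy for Hydroxymethyl at a Chain End Already Inactive

The source may report more compounds than this note shows. Statements on the series, on what has been measured and on what is new or still open speak of the compounds shown alone.

Compound 1 `Cn1c(Cc2nn(CCC3OCCO3)c(=O)c3ccccc23)nnc1SCC(=O)Nc1ccc(Cl)cc1Cl`: > 30000 nM
Compound 2 `Cn1c(Cc2nn(CCC=O)c(=O)c3ccccc23)nnc1SCC(=O)Nc1ccc(Cl)cc1Cl`: 30000 nM
Compound 3 `Cn1c(Cc2nn(CCCO)c(=O)c3ccccc23)nnc1SCC(=O)Nc1ccc(Cl)cc1Cl`: > 30000 nM

In an assay on 32D cells for inhibition of interleukin-15 (Mus musculus), read by resazurin assay, with stated times of 30 min and 2.5 days, in the presence of a further agent that is not named here (a higher number here means a weaker inhibitor, a lower number a stronger inhibitor), compound 1 gives only a limit, > 30000 nM. Compound 2 gives 30000 nM. Compound 3 likewise gives only a limit, > 30000 nM, so it stands at the top of the numbers shown, where (the limit of > 30000 nM in this assay, at which 2 of the 3 values shown sit). The steps into compound 3 are a step that the two limits leave unreadable from compound 1 to compound 3 and a number no lower from compound 2 to compound 3 (the limit leaves the size open), neither of readable size. Compound 4 `Cn1c(Cc2nn(CCC(=O)O)c(=O)c3ccccc23)nnc1SCC(=O)Nc1ccc(Cl)cc1Cl` differs from compound 3 by carboxy in place of hydroxymethyl on a saturated chain carbon, two bonds along the chain from an aromatic nitrogen. Among the measured compounds shown here, no measured step bears directly on this change, and every step so far ends at or near the limit, so no step beyond the scatter is expected in this assay. Compound 4 is therefore expected to remain at the limit, estimated at 30000 nM, between 15000 nM and 60000 nM, a step of a number no higher from compound 3 to compound 4 (the limit leaves the size open).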

Compound 4, half-maximal inhibitory concentration: > 30000 nM
Compound 4 gave a limit, no number (the forecaster's own chance of this, stated with the estimate: 85%); the middle value lies on the limit itself.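

In this assay compound 4 also gives only a limit, > 30000 nM, so carboxy on a saturated chain carbon, two bonds along the chain from an aromatic nitrogen, brings no measurable value. None of the new steps can be read in size, and the only one with a direction is a number no lower from compound 2 to compound 4 (the limit leaves the size open). This chain end has now carried 1,3-dioxolan-2-yl, formyl, hydroxymethyl and carboxy with no value clear of the top of the range: the limit of > 30000 nM in this assay, at which 3 of the 4 values shown sit.

From the compounds shown here alone, whether an amine or a longer chain at this place would give a value clear of the limit stays open. So does whether any change to the shared core would.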